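Thiophenyl-to-benzyl thioether swap in a growth-inhibition series

A few compounds are considered here, and "the series" means these few. Any claim that something is new, unique, unknown or untested is made for them only; others in the source may bear on it.

Compound 1: `COc1ccc(/C=C(/Sc2ccc(C)cc2)C(=O)c2ccc(Cl)cc2)cc1O` — 1000 nM
Compound 2: `Cc1ccc(/C=C(\C(=O)c2ccc(Cl)cc2)S(=O)(=O)Cc2ccc(Cl)cc2Cl)s1` — 10000 nM
Compound 3: `Cc1ccc(S/C(=C/c2ccc(Br)cc2)C(=O)c2ccc(Cl)cc2)cc1` — 25000 nM

Three compounds sharing an enone core were tested in a functional assay on DU-145 cells (Homo sapiens) for inhibition, read by trypan blue exclusion, with a stated time of 96 h; on this read-out higher numbers stand for weaker inhibition of growth and lower numbers for stronger inhibition of growth. Compound 1 gives 1000 nM, compound 2 gives 10000 nM, and compound 3 gives 25000 nM, the highest of the three numbers; compound 2 stands nearest to it and compound 1 furthest. Among the measured compounds shown here, the only single-point step among them is a 25-fold higher number from compound 1 to compound 3 (1.40 log units; beyond the scatter), a large change, but it concerns the aryl group on the chain carbon and not the sulfur substituent.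

Compound 4, `O=C(/C(=C\c1ccc(Br)cc1)SCc1ccc(Cl)cc1)c1ccc(Cl)cc1`, differs from compound 3 by 4-chlorobenzyl in place of 4-methylphenyl on a sulfur. For the measured compounds named here, no measured step touches this sulfur substituent: compound 2 carries a benzyl group on its sulfur, but it also differs in the oxidation state of that sulfur and in the aryl group, so its value shows only that such a combination can sit between compound 1 and compound 3. Going by the values given here, with no step bearing on the change, no move beyond the scatter in this assay can be foreseen in either direction, and a wide range is appropriate.

Compound 4 is therefore expected to give about 20000 nM, within 5000 nM to 60000 nM. This estimate amounts to a 1.3-fold lower number from compound 3 to compound 4 (0.10 log units; within the scatter).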

Compound 4, concentration for 50% growth inhibition: 1000 nM
For compound 4 the middle estimate is 20-fold (1.30 log units) above the measured one; measured number below the stated range.
By their numbers in this assay, from the lowest: compounds 1 and 4 (each within the scatter of the next); then compound 2; then compound 3.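

In this assay the substituent on the sulfur proves to be a position of large effect: 4-chlorobenzyl in place of 4-methylphenyl gives a 25-fold lower number from compound 3 to compound 4 (1.40 log units; beyond the scatter) with the 4-bromophenyl group and the rest of the molecule unchanged. The aryl group on the chain carbon is therefore not the only place shown to move this number by a large step, as a 25-fold higher number from compound 1 to compound 3 (1.40 log units; beyond the scatter) had suggested on its own. No measurement at hand accounts for the size or the direction of the new step.

The compounds shown leave open whether the step follows the extra carbon of the benzyl group or the chlorine in place of the methyl group, which a plain benzyl or a 4-methylbenzyl group on the sulfur would separate. From the compounds shown here alone, it is also open whether the same change holds with the 3-hydroxy-4-methoxyphenyl group on the chain carbon.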